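From cyclopropyl to cyclohexyl on a stable compound

A few compounds are considered here, and "the series" means these few. Any claim that something is new, unique, unknown or untested is made for them only; others in the source may bear on it.

In an ADME assay on microsomes from liver (Mus musculus) for metabolic stability, read by LC-MS, with a stated time of 10 min (on this read-out higher numbers stand for a more stable compound and lower numbers for a less stable compound), compound 1 (`c1cnc2c(c1)CCC[C@@H]2N(CC1CC1)C[C@H]1Cc2c(cccc2N2CCNCC2)CN1`) gives 88.3% and holds the higher of the two numbers at hand. Compound 2 (`CN(C[C@H]1Cc2c(cccc2N2CCN(Cc3ccccn3)CC2)CN1)[C@H]1CCCc2cccnc21`) stands at 40.4% and so lies below compound 1 by a gap beyond the scatter.

Compound 3 (`c1cnc2c(c1)CCC[C@@H]2N(CC1CCCCC1)C[C@H]1Cc2c(cccc2N2CCNCC2)CN1`) keeps the core of compound 1 and carries cyclohexyl in place of cyclopropyl on a saturated chain carbon bound to an amine nitrogen. Among the measured compounds shown here, no measured pair shows this change or any other change in one place, so the expectation has little to rest on. With compound 1 at 88.3% there is little room for a rise, and compound 2 at 40.4% shows that much lower numbers occur in this small set.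

The expected step in this assay is a fall beyond the scatter, estimated as a number 30.3 percentage points lower from compound 1 to compound 3 (beyond the scatter) with wide uncertainty. For compound 3 the estimated value is 58% with 32% to 82% as the expected range.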

Compound 3, percent of the compound remaining: 85.6%
For compound 3 the middle estimate is 27.6 percentage points below the measured one; the whole stated range lies below it.
By their numbers in this assay, from the lowest: compound 2; then compounds 3 and 1 (each within the scatter of the next).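

In this assay, cyclohexyl in place of cyclopropyl on a saturated chain carbon bound to an amine nitrogen gives a number 2.7 percentage points lower from compound 1 to compound 3 (within the scatter). Among the compounds shown here, this is the only pair in the set that differs in one place, and it shows that this position accepts cyclopropylmethyl and cyclohexylmethyl with no difference that can be told from the scatter, so the reading stays in the same range with either ring on the core of compound 1. Nothing at hand explains why the read-out holds through this change, so the result stands as an observation only.

For the compounds shown here, the two rings are the only groups compared at this position, so it remains open whether a phenyl ring, a piperidinyl ring carrying a ring amine, a carboxylic acid or a longer open alkyl chain would read the same there. Going by these compounds, compound 2 differs from compound 1 in more than one place, so it remains open whether the same swap would also leave the reading within the scatter on a core whose piperazine nitrogen carries a substituent.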